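Benzyl on the phenolic oxygen of compound 3

The compounds below may be only part of what the source reports. "The series", "measured", "known", "first", "only" and "open" are said of these compounds alone.

Compound 1: `CNc1ncnc2c1ncn2Cc1ccc(F)cc1`, 33%
Compound 2: `CNc1ncnc2c1ncn2Cc1ccc([N+](=O)[O-])cc1`, 0%
Compound 3: `CNc1ncnc2c1ncn2Cc1cccc(O)c1`, 0%

Of the compounds shown here, three sharing one core have been tested in a functional assay on the whole organism with Rattus norvegicus as the target, in the maximal electroshock model, at a dose of 25 mg/kg by the intraperitoneal route; on this read-out lower numbers stand for less inhibition and higher numbers for more inhibition at the one dose given (going by the name of the read-out). Compound 1 `CNc1ncnc2c1ncn2Cc1ccc(F)cc1` gives 33% in this assay. Among the measured compounds shown here, compound 2 `CNc1ncnc2c1ncn2Cc1ccc([N+](=O)[O-])cc1` gives 0%, and the single measured step, a number 33 percentage points lower from compound 1 to compound 2 (beyond the scatter), is large and beyond the scatter. Compound 3 `CNc1ncnc2c1ncn2Cc1cccc(O)c1` gives 0% in this assay, level with compound 2 at the digits shown; the two together stand at the lowest number, and compound 1 sits above both by a margin that is beyond the scatter.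

The unmeasured compound 4 `CNc1ncnc2c1ncn2Cc1cccc(OCc2ccccc2)c1` differs from compound 3 by one change: benzyl in place of hydrogen on an oxygen on an aromatic ring. For the measured compounds named here, no measured step touches this position or this kind of group; the only step available, from fluoro to nitro on the aromatic ring, is a different change at a different place, so it gives no direct guide. What the numbers do show is that the aromatic substituents tried so far have ranged from no inhibition to moderate inhibition, and a group as large as benzyl has not been tried. Compound 4 is therefore expected to move by a number 20 percentage points higher from compound 3 to compound 4 (beyond the scatter), a rise of uncertain size. Compound 4 is estimated at 20%, with a range from 0% to 60%.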

Compound 4, a percentage reported as inhibition, in the whole organism at one dose (the size of the read-out at that dose, not a potency): 17%
The estimate for compound 4 lay 3 percentage points above the measured number; the measured number falls inside the stated range.
By their numbers in this assay, from the lowest: compounds 2 and 3 (each within the scatter of the next); then compound 4; then compound 1.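

Compound 3 had shown only that a free hydroxy on this aromatic ring gives no inhibition at the one dose tested, which left open whether any group at this place could register in this assay. Replacing the hydrogen on that oxygen with benzyl, the change from hydroxy to benzyloxy, gives a number 17 percentage points higher from compound 3 to compound 4 (beyond the scatter), a modest step but the first to show that the number responds to what is carried on this oxygen. A group with a six-membered aromatic ring of carbon only is therefore compatible with measurable inhibition here, although this rests on a single pair of compounds at a single dose. Nothing in the data gives a reason for the rise.

The compounds shown leave open whether the aromatic ring of the benzyl is needed, or whether a methyl or a longer alkyl chain on the same oxygen would give a similar number. They also leave open how this assay would respond to a fluoro on the ring of the benzyl, or to an amine at the end of a chain on that oxygen.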